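Moving the sulfamide one bond further out from the ring

The compounds below may be only part of what the source reports. "The series", "measured", "known", "first", "only" and "open" are said of these compounds alone.

Compound 1, `NS(=O)(=O)NCC1CCN(c2cc(-c3ccccc3)ncn2)CC1`: in a functional assay on M21 cells (Homo sapiens) for antiproliferative activity, read by sulforhodamine B assay, with a stated time of 48 h (on this read-out higher numbers stand for weaker inhibition of growth and lower numbers for stronger inhibition of growth), compound 1 reaches only the assay limit of > 100000 nM.
Compound 2, `NS(=O)(=O)NCC1CCN(c2cc(-c3ccccc3F)ncn2)CC1`: in this assay compound 2 likewise reaches only the limit of > 100000 nM.
Compound 3, `NS(=O)(=O)NCC1CCN(c2cc(-c3cccc4ccccc34)ncn2)CC1`: in this assay compound 3 gives 6600 nM.

Among the measured compounds shown here, compound 3 thus stands alone as the only measured number; the two other values are limits (the limit of > 100000 nM in this assay, at which 2 of the 3 values shown sit). For the measured compounds named here, the only step between two measured compounds, a step that the two limits leave unreadable from compound 1 to compound 2, cannot be read. Compound 4, `NS(=O)(=O)NCCC1CCN(c2cc(-c3cccc4ccccc34)ncn2)CC1`, differs from compound 3 in one place: (sulfamoylamino)methyl in place of sulfamoylamino on a saturated chain carbon bound to a saturated ring carbon. Going by the values given here, no measured step concerns this kind of change, so nothing here argues for a move beyond the usual scatter in this assay in either direction. Compound 4 is therefore expected at 6600 nM, with a range of 2000 nM to 25000 nM. The expected step of no change at the digits printed from compound 3 to compound 4 (within the scatter) would stay within scatter.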

Compound 4, concentration for 50% growth inhibition: 1800 nM
Estimate against measurement, compound 4: 3.7-fold (0.56 log units) above; measured number below the stated range.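

In this assay, among the compounds shown here, the longer chain gives a 3.7-fold lower number from compound 3 to compound 4 (0.56 log units; beyond the scatter) and thus the first readable step at this position. The sidechain length therefore matters here: one added carbon, with the sulfamide itself unchanged, moves the read-out modestly towards stronger inhibition of growth. Nothing shown here accounts for this gain.

On these data alone, whether a still longer chain, such as 2-(sulfamoylamino)ethyl, would strengthen inhibition further remains open. So does whether an amine or a carboxylic acid could stand in place of the sulfamide at the end of the chain.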